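This account rests on a few compounds, and the source may have more. Where it says the series, first, only, none or still open, it means among the compounds named here.

Working notes on the series in a functional assay on NCI-H460 cells (Homo sapiens) for cytotoxicity, read by MTT assay, with a stated time of 72 h; a higher number here means a weaker inhibitor, a lower number a stronger inhibitor. Compound 1 `COc1cc(/C=C2\CNC/C(=C\c3cc(OC)c(OC)c(OC)c3)C2=O)cc(OC)c1OC` gives 1500 nM. Compound 3 `COc1cc(/C=C2\CN(C(=O)C(C)C)C/C(=C\c3cc(OC)c(OC)c(OC)c3)C2=O)cc(OC)c1OC` gives 2000 nM, so a 1.3-fold higher number from compound 1 to compound 3 (0.12 log units; within the scatter) leaves it level with compound 1. Compound 2 `COc1cc(/C=C2\CN(C(=O)CCC(=O)O)C/C(=C\c3cc(OC)c(OC)c(OC)c3)C2=O)cc(OC)c1OC` reads > 60000 nM, and this is a limit of the assay, not a number. The two large steps, an at least 40-fold higher number from compound 1 to compound 2 (1.60 log units; beyond the scatter) and an at least 30-fold lower number from compound 2 to compound 3 (1.47 log units; beyond the scatter), both concern the 2-carboxyethyl group, which plays no part in the next change.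

Compound 4 `COc1cc(/C=C2\CN(C(=O)c3ccccc3F)C/C(=C\c3cc(OC)c(OC)c(OC)c3)C2=O)cc(OC)c1OC` has 2-fluorophenyl in place of isopropyl on a carbonyl carbon. The closest guide is the step to compound 3, a 1.3-fold higher number from compound 1 to compound 3 (0.12 log units; within the scatter), which shows that a carbonyl group without the acid can sit on the ring nitrogen with no shift beyond the scatter. Going by the values given here, no measured step tests an aromatic ring at this place, so the estimate stays wide. In this assay the expected change is small, with no clear direction: a 1.3-fold lower number from compound 3 to compound 4 (0.12 log units; within the scatter). For compound 4 the estimated value is 1500 nM, with an expected range of 400 nM to 5000 nM.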

Compound 4, half-maximal inhibitory concentration: 1500 nM
For compound 4 middle estimate and measured number coincide at the digits printed, within the range that was stated.
By their numbers in this assay, from the lowest: compounds 1, 4 and 3 (each within the scatter of the next). At a limit, above all of these: compound 2.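

In this assay, an aromatic ring on this carbonyl carbon changes nothing beyond the scatter: a 1.3-fold lower number from compound 3 to compound 4 (0.12 log units; within the scatter), and no change at the digits printed from compound 1 to compound 4 (within the scatter). Among the groups on the ring nitrogen, hydrogen, isopropylcarbonyl and (2-fluorophenyl)carbonyl therefore give level numbers, and only compound 2 goes against this pattern. Compound 2 remains a limit of the assay, so an at least 40-fold lower number from compound 2 to compound 4 (1.60 log units; beyond the scatter) is a bound and not a measured gap: the limit of > 60000 nM in this assay, at which 1 of the 4 values shown sits.

A plain phenyl on this carbonyl carbon would show whether the fluorine in 2-fluorophenyl counts for anything here. A methyl ester in place of the carboxylic acid of compound 2 would show whether the loss of activity goes with the acid itself or with the chain that carries it.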